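The source may report more compounds than this note shows. Statements on the series, on what has been measured and on what is new or still open speak of the compounds shown alone.

Measured compounds:
compound 1, `Cc1coc(C(=O)CCCCCCc2ccccc2)n1`, gives 520 nM;
compound 2, `O=C(CCCCCCc1ccccc1)c1nc(-c2ccccn2)co1`, gives 1.9 nM;
compound 3, `O=C(CCCCCCc1ccccc1)c1nc(-c2ccncc2)co1`, gives 1.6 nM.

All three were tested in an assay on isolated protein for inhibition of Fatty-acid amide hydrolase 1 (Rattus norvegicus); a higher number here means a weaker inhibitor, a lower number a stronger inhibitor. Compound 3 has the lowest number of the three, but its step to compound 2 is small: a 1.2-fold lower number from compound 2 to compound 3 (0.07 log units; within the scatter). The two steps from compound 1 are large: a 270-fold lower number from compound 1 to compound 2 (2.44 log units; beyond the scatter) and a 330-fold lower number from compound 1 to compound 3 (2.51 log units; beyond the scatter).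

Compound 4, `O=C(CCCCCCc1ccccc1)c1nc(-c2ccccc2)co1`, has not yet been measured. The change from compound 3 is phenyl in place of pyridin-4-yl on an aromatic carbon. The measured steps show that a six-membered aromatic ring in that position, in place of methyl, lowers the number strongly, and that exchanging one pyridyl isomer for the other changes little. Compound 4 keeps a six-membered aromatic ring there. Among the compounds with values here, no step with a phenyl at that position has been measured, so the expectation rests on the two pyridyl compounds alone.

Compound 4 is expected to give 3.5 nM, within 1.2 nM to 10 nM, an estimated step of a 2.2-fold higher number from compound 3 to compound 4 (0.34 log units; beyond the scatter), that is, a small change or none beyond the scatter.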

Compound 4, inhibition constant: 65 nM
Beside the measured number, compound 4's estimate is 19-fold (1.27 log units) below it, outside the stated range (above it).
By their numbers in this assay, from the lowest: compounds 3 and 2 (each within the scatter of the next); then compound 4; then compound 1.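

Exchanging pyridin-4-yl for phenyl keeps the six-membered aromatic ring and the heavy-atom count but replaces the ring nitrogen, a hydrogen-bond acceptor, with carbon, and this assay shows a 41-fold higher number from compound 3 to compound 4 (1.61 log units; beyond the scatter) for this change. The same loss appears with the other pyridyl compound as a 34-fold higher number from compound 2 to compound 4 (1.53 log units; beyond the scatter) and so, although the two pyridyl isomers gave matching numbers, a ring nitrogen at this position matters, not just the presence of an aromatic ring. Phenyl alone still gives an 8.0-fold lower number from compound 1 to compound 4 (0.90 log units; beyond the scatter) as a modest gain over methyl, much smaller than a 270-fold lower number from compound 1 to compound 2 (2.44 log units; beyond the scatter) for the pyridin-2-yl group, and nothing measured here explains that gap.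

From the compounds shown here alone, whether pyridin-3-yl would match the two pyridyl compounds remains open. So does whether a phenyl ring carrying an amino group or a carboxylic acid would bring the number back down.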